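Swapping nitro for methoxy on the aryl tail of compound 2

The source may hold more compounds than are shown below. What is called first, only, known or untested is meant among the compounds shown, and "the series" means these compounds.

Measured compounds:
compound 1 `O=c1[nH]/c(=N\OCCOc2ccccc2)ccn1[C@@H]1O[C@H](COP(=O)(O)OP(=O)(O)OP(=O)(O)O)[C@@H](O)[C@H]1O` — 430 nM
compound 2 `O=c1[nH]/c(=N\OCCCc2ccc([N+](=O)[O-])cc2)ccn1[C@@H]1O[C@H](COP(=O)(O)OP(=O)(O)OP(=O)(O)O)[C@@H](O)[C@H]1O` — 84 nM

Going by the values given here, in a functional assay on 1321-N1 cells for agonist activity at P2Y purinoceptor 4 (Homo sapiens), read by scintillation counting and inositol phosphate accumulation (on this read-out lower numbers stand for an effect already at smaller amounts and higher numbers for an effect only at larger amounts of compound), compound 2 gives 84 nM, the lowest of the two numbers; its nearest neighbour is compound 1, and the one measured step, a 5.1-fold lower number from compound 1 to compound 2 (0.71 log units; beyond the scatter), separates them. Compound 3 `COc1ccc(CCCO/N=c2/ccn([C@@H]3O[C@H](COP(=O)(O)OP(=O)(O)OP(=O)(O)O)[C@@H](O)[C@H]3O)c(=O)[nH]2)cc1` keeps the shared core and the same three-carbon chain as compound 2 and changes only the aromatic ring: methoxy in place of nitro on an aromatic carbon, para to a large group. Among the compounds with values here, no measured step covers this exchange; the step from compound 1 to compound 2 concerns the tail as a whole and bears on it only loosely. In this assay the expected outcome is therefore a small shift, a 1.8-fold higher number from compound 2 to compound 3 (0.25 log units; within the scatter), which could fall within the scatter. Compound 3 is estimated at 150 nM, in the range 50 nM to 500 nM.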

Compound 3, half-maximal effective concentration: 23 nM
Compound 3: the middle estimate sits 6.5-fold (0.81 log units) above what was measured, outside the stated range (below it).
By their numbers in this assay, from the lowest: compound 3; then compound 2; then compound 1.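

In this assay, the aromatic carbon para to a large group proves to matter on its own: methoxy in place of nitro gives a 3.7-fold lower number from compound 2 to compound 3 (0.56 log units; beyond the scatter), whereas the earlier step changed the whole tail at once. A nitro group is therefore not needed at this position for a low number, and the exchange moves the number further in the same direction as the earlier tail change. Taken as a whole, the 4-methoxybenzyl tail in place of phenoxy gives a 19-fold lower number from compound 1 to compound 3 (1.27 log units; beyond the scatter), a large step, but nothing available explains why methoxy does better than nitro here.

Two groups at one position do not establish a trend. As far as these compounds go, whether an amine or a carboxylic acid at this carbon, or a longer chain leading to the ring, would lower the number further remains open.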